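Shortening a hydroxyalkoxy chain on the anilino headgroup

This account rests on a few compounds, and the source may have more. Where it says the series, first, only, none or still open, it means among the compounds named here.

Measured compounds in a functional assay on A549 cells (Homo sapiens) for antiproliferative activity, read by sulforhodamine B assay, with a stated time of 72 h; on this read-out lower numbers stand for stronger inhibition and higher numbers for weaker inhibition:
compound 1 `COc1ncc(-c2ccc3ncnc(Nc4ccc(OCCO)c(F)c4)c3c2)cc1NS(=O)(=O)c1ccc(F)cc1F`: 6640 nM
compound 2 `COc1cc(Nc2ncnc3ccc(-c4cnc(OC)c(NS(=O)(=O)c5ccc(F)cc5F)c4)cc23)ccc1OCCO`: 3760 nM
compound 3 `COc1ncc(-c2ccc3ncnc(Nc4ccc(OCCCO)nc4)c3c2)cc1NS(=O)(=O)c1ccc(F)cc1F`: 9360 nM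

Compound 3 gives the highest number of the three, but its nearest neighbour is compound 1, where a 1.4-fold higher number from compound 1 to compound 3 (0.15 log units; within the scatter). Only the gap to compound 2 is beyond the scatter, where a 2.5-fold higher number from compound 2 to compound 3 (0.40 log units; beyond the scatter). Compound 1 and compound 2 lie close to one another, where a 1.8-fold lower number from compound 1 to compound 2 (0.25 log units; within the scatter).

Compound 4 `COc1ncc(-c2ccc3ncnc(Nc4ccc(OCCO)nc4)c3c2)cc1NS(=O)(=O)c1ccc(F)cc1F` is the next step. Relative to compound 3 the change is hydroxy in place of hydroxymethyl on a saturated chain carbon, two bonds along the chain from an oxygen on an aromatic ring, so the pyridinyl headgroup keeps its oxygen on the aromatic ring but carries a shorter chain.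

Among the measured compounds shown here, no measured step isolates this chain shortening. The step from compound 1 to compound 3 changes both the ring and the chain at once and stays within the scatter, and the other two steps concern substituents on the phenyl headgroup. The three measured numbers span only a narrow band. Compound 4 is therefore expected to stay within that band, and the step of a 1.2-fold lower number from compound 3 to compound 4 (0.07 log units; within the scatter) is estimated to fall within the scatter. For compound 4 the estimate in this assay is 8000 nM, with a range from 3500 nM to 18000 nM.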

Compound 4, half-maximal inhibitory concentration: 4120 nM
Beside the measured number, compound 4's estimate is 1.9-fold (0.29 log units) above it; low and high end bracket the measured number.
By their numbers in this assay, from the lowest: compounds 2, 4, 1 and 3 (each within the scatter of the next, the first and the last beyond it).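

In this assay, among the compounds shown here, the change from 3-hydroxypropoxy to 2-hydroxyethoxy on the pyridinyl headgroup is the first change of chain length that can be read on its own, and a 2.3-fold lower number from compound 3 to compound 4 (0.36 log units; beyond the scatter) shows that this chain length matters modestly at this position. With the 2-hydroxyethoxy chain now common to all three compounds, the headgroup can also be compared without a change in chain length: a 1.1-fold higher number from compound 2 to compound 4 (0.04 log units; within the scatter) and a 1.6-fold lower number from compound 1 to compound 4 (0.21 log units; within the scatter) both leave the pyridinyl headgroup indistinguishable from the two substituted phenyl headgroups, whereas compound 3, with its longer chain, stood clearly apart only from compound 2. Nothing in the material shown explains the step on shortening the chain.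

The compounds shown give only two chain lengths, both on the pyridinyl headgroup, so they cannot say whether a longer chain such as 4-hydroxybutoxy would raise the number further or whether the 3-hydroxypropoxy chain would behave the same way on a phenyl headgroup. They also leave open whether an amine or a carboxylic acid in place of the hydroxy at the chain end would keep the number in this range.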